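The source may report more compounds than this note shows. Statements on the series, on what has been measured and on what is new or still open speak of the compounds shown alone.

Measured in a functional assay on CCRF-CEM cells (Homo sapiens) for inhibition; on this read-out higher numbers stand for weaker inhibition and lower numbers for stronger inhibition:
compound 1, `CCC(C)C(NC(=O)n1nnc2ccccc21)C(=O)NC1CCCCC1`: 107000 nM
compound 2, `CCC(C)C(NC(=O)n1nnc2ccccc21)C(=O)NCc1ccccc1`: 164000 nM
compound 3, `CCC(C)C(NC(=O)n1nnc2ccccc21)C(=O)NC1CCCC1`: 116000 nM

Compound 1 carries the lowest of the three numbers, but its gap to compound 3, a 1.1-fold higher number from compound 1 to compound 3 (0.04 log units; within the scatter), and its gap to compound 2, a 1.5-fold higher number from compound 1 to compound 2 (0.19 log units; within the scatter), both lie within the scatter, so the three compounds stand level in this assay. Every measured step changes the group on the amide-type nitrogen; none touches the side chain.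

Compound 4, `CC(C)C(NC(=O)n1nnc2ccccc21)C(=O)NC1CCCCC1`, differs from compound 1 by hydrogen in place of methyl on a saturated chain carbon, three bonds along the chain from an amide-type nitrogen and a carbonyl carbon. For the measured compounds named here, no measured step bears on this change, so the expectation rests on compound 1 alone at 107000 nM. Nothing in the series points to a step beyond the scatter in this assay. Compound 4 is therefore expected near 130000 nM, with a range of 50000 nM to 350000 nM. The expected step is a 1.2-fold higher number from compound 1 to compound 4 (0.08 log units; within the scatter).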

Compound 4, half-maximal inhibitory concentration: 112000 nM
Compound 4: the middle estimate sits 1.2-fold (0.06 log units) above what was measured; the measured number falls inside the stated range.
By their numbers in this assay, from the lowest: compounds 1, 4, 3 and 2 (each within the scatter of the next).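

The side chain now has a step of its own: sec-butyl to isopropyl gives a 1.0-fold higher number from compound 1 to compound 4 (0.02 log units; within the scatter) in this assay, so removing this methyl leaves the number as level as the changes on the amide-type nitrogen did. No measured evidence on hand bears on this flat result. On these data alone, whether an amine, a carboxylic acid or a longer chain at this carbon would move the number beyond the scatter remains open. Also open, as far as these compounds go, is whether the same methyl change reads alike with benzyl or cyclopentyl on the nitrogen.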